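Propargyl ether to 2-bromobenzyl ether on a shared core

The source may report more compounds than this note shows. Statements on the series, on what has been measured and on what is new or still open speak of the compounds shown alone.

Compound 1, `C#CCOc1ccc2c(=O)c(-c3cc(OC)c(OC)cc3OC)coc2c1`, was run in a functional assay on A-375 cells (Homo sapiens) for antiproliferative activity, read by MTT assay, with a stated time of 24 h (on this read-out lower numbers stand for stronger inhibition and higher numbers for weaker inhibition), where compound 1 gives 3680 nM. Going by the values given here, of the two numbers known in this assay, that of compound 1 is the higher; its nearest neighbour is compound 2, `COc1cc(OC)c(-c2coc3cc(OCc4ccccc4F)ccc3c2=O)cc1OC`, which in this assay gives 2100 nM, and the step of a 1.8-fold lower number from compound 1 to compound 2 (0.24 log units; within the scatter). Compound 3, `COc1cc(OC)c(-c2coc3cc(OCc4ccccc4C(F)(F)F)ccc3c2=O)cc1OC`, in this assay reaches only a limit, > 10000 nM. That limit is the limit of > 10000 nM in this assay, at which 1 of the 3 values shown sits. Measured from the others, the steps read an at least 2.7-fold higher number from compound 1 to compound 3 (0.43 log units; beyond the scatter) and an at least 4.7-fold higher number from compound 2 to compound 3 (0.67 log units; beyond the scatter).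

Compound 4, `COc1cc(OC)c(-c2coc3cc(OCc4ccccc4Br)ccc3c2=O)cc1OC`, is not yet measured in this assay. Against compound 1 it shows (2-bromophenyl in place of ethynyl on a saturated chain carbon bound to an oxygen on an aromatic ring). The two measured steps that bear on it swap the same ethynyl for a substituted phenyl: one moved little, the other pushed the number past the limit. A bromine on that ring is expected to fall between those outcomes, so compound 4 is estimated at 5000 nM, within 2000 nM to 14000 nM. The expected step is a 1.4-fold higher number from compound 1 to compound 4 (0.13 log units; within the scatter).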

Compound 4, half-maximal inhibitory concentration: 2850 nM
Compound 4: the middle estimate sits 1.8-fold (0.24 log units) above what was measured; measured number inside the range.
By their numbers in this assay, from the lowest: compounds 2, 4 and 1 (each within the scatter of the next). At a limit, above all of these: compound 3.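

Putting 2-bromophenyl in place of ethynyl on this saturated chain carbon leaves the number within the scatter, with a 1.3-fold lower number from compound 1 to compound 4 (0.11 log units; within the scatter), and bromo in place of fluoro on the aromatic carbon does the same, with a 1.4-fold higher number from compound 2 to compound 4 (0.13 log units; within the scatter). In this assay, the added ring therefore need not cost activity, and trifluoromethyl alone goes against this among the three substituents shown, with an at least 3.5-fold lower number from compound 3 to compound 4 (0.54 log units; beyond the scatter). The value of compound 3 remains a limit rather than a number: the limit of > 10000 nM in this assay, at which 1 of the 4 values shown sits.

The compounds shown carry only fluoro, bromo or trifluoromethyl on the added ring, so it remains open how a plain phenyl, an amine or a nitrile would read there. They also do not show why trifluoromethyl stands apart from bromo and fluoro.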